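Replacing the amino side chain of compound 3

A few compounds are considered here, and "the series" means these few. Any claim that something is new, unique, unknown or untested is made for them only; others in the source may bear on it.

In a functional assay on RS4-11 cells (Homo sapiens) for inhibition, read by CCK-8 assay, with a stated time of 72 h (on this read-out lower numbers stand for stronger inhibition and higher numbers for weaker inhibition), compound 3 `CC1(C)CCC(CN2CCN(c3ccc(C(=O)NS(=O)(=O)c4ccc(NCC5CCOC5)c([N+](=O)[O-])c4)c(Oc4cnc5[nH]ccc5c4)c3)CC2)=C(c2ccc(C(F)(F)F)cc2)C1` gives 24.2 nM and is the lowest of three numbers, with compound 1 `CC1(C)CCC(CN2CCN(c3ccc(C(=O)NS(=O)(=O)c4ccc(NCC5CCOCC5)c([N+](=O)[O-])c4)c(Oc4cnc5[nH]ccc5c4)c3)CC2)=C(c2cccc(C(F)(F)F)c2)C1` at 63 nM and compound 2 `CC1(C)CCC(CN2CCN(c3ccc(C(=O)NS(=O)(=O)c4ccc(NCC5CCOCC5)c([N+](=O)[O-])c4)c(Oc4cnc5[nH]ccc5c4)c3)CC2)=C(c2ccc(C(F)(F)F)c(Cl)c2)C1` at 81 nM standing higher. Compound 4 `CN1CCC(COc2ccc(S(=O)(=O)NC(=O)c3ccc(N4CCN(CC5=C(c6ccc(C(F)(F)F)cc6)CC(C)(C)CC5)CC4)cc3Oc3cnc4[nH]ccc4c3)cc2[N+](=O)[O-])C1` carries (1-methylpyrrolidin-3-yl)methoxy in place of ((oxolan-3-yl)methyl)amino on an aromatic carbon and otherwise matches compound 3. Among the compounds with values here, the one measured step of a 1.3-fold higher number from compound 1 to compound 2 (0.11 log units; within the scatter) stays within the scatter and sits elsewhere in the molecule, so no measured step speaks directly to this swap. Since compound 3 at 24.2 nM is the lowest so far, a modest rise is the cautious expectation. The expected step in this assay is a 1.7-fold higher number from compound 3 to compound 4 (0.22 log units; within the scatter) with wide uncertainty. For compound 4 the estimated value is 40 nM within an expected range of 10 nM to 150 nM on this measurement.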

Compound 4, half-maximal inhibitory concentration: 10 nM
Beside the measured number, compound 4's estimate is 4.0-fold (0.60 log units) above it, within the range that was stated.
By their numbers in this assay, from the lowest: compound 4; then compound 3; then compounds 1 and 2 (each within the scatter of the next).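

The side chain ortho to a nitro group responds to this swap: in this assay there is a 2.4-fold lower number from compound 3 to compound 4 (0.38 log units; beyond the scatter). The entering (1-methylpyrrolidin-3-yl)methoxy has 0 hydrogen-bond donors where ((oxolan-3-yl)methyl)amino has 1, so in this pair a low number does not depend on a donor at this place. No measurement shown explains the shift.

The swap alters the linking atom and the ring together, and the compounds shown do not separate the two. A ((1-methylpyrrolidin-3-yl)methyl)amino chain, keeping the amino link with the new ring, would tell them apart.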